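The compounds below may be only part of what the source reports. "The series", "measured", "known", "first", "only" and "open" are said of these compounds alone.

Measured compounds:
compound 1 `OCCNCc1nc2c(OCC3CCCCC3)cccc2[nH]1`: 63.3%
compound 2 `CC(C)(CO)NCc1nc2c(OCC3CCCCC3)cccc2[nH]1`: 54.7%
compound 3 `OCCC(NCc1nc2c(OCC3CCCCC3)cccc2[nH]1)c1ccccc1`: 64.7%

All three share one core and differ only in the group carried on the amine nitrogen. In an assay on cells for inhibition of interleukin-5 receptor subunit alpha (Mus musculus), read by WST assay, with a stated time of 48 h, tested at 30 uM, in the presence of a further agent that is not named here (on this read-out lower numbers stand for less inhibition and higher numbers for more inhibition at the one concentration tested (going by the name of the read-out)), compound 1 gives 63.3%, which is the second highest of the three numbers. Compound 3 gives 64.7%, and compound 2 gives 54.7%; both values sit within the usual scatter of the value for compound 1, so no order among the three can be read from them.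

The unmeasured compound 4 `OCC(CC1CCCCC1)NCc1nc2c(OCC3CCCCC3)cccc2[nH]1` is reached from compound 1 by one change: cyclohexylmethyl in place of hydrogen on a saturated chain carbon bound to an amine nitrogen and a saturated chain carbon. Among the compounds with values here, the one measured step that bears on this is the change on the amine substituent, a number 8.6 percentage points lower from compound 1 to compound 2 (within the scatter), which lay within the scatter. Compound 3 likewise carries a larger group on the chain next to the amine nitrogen and its value stays close to that of compound 1. Enlarging the group on this amine-bearing chain has so far not moved the read-out beyond the scatter, so for compound 4 a step of about a number 1.3 percentage points lower from compound 1 to compound 4 (within the scatter) is expected in this assay, that is, none beyond the scatter. Compound 4 is therefore estimated at 62%, with a range from 46% to 78%.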

Compound 4, a percentage reported as inhibition, at one concentration (the size of the read-out at that concentration, not a potency): 94.7%
For compound 4 the middle estimate is 32.7 percentage points below the measured one; the measured number lies above the stated range.
By their numbers in this assay, from the lowest: compounds 2, 1 and 3 (each within the scatter of the next); then compound 4.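

In this assay, cyclohexylmethyl in place of hydrogen on a saturated chain carbon bound to an amine nitrogen and a saturated chain carbon gives a number 31.4 percentage points higher from compound 1 to compound 4 (beyond the scatter). This shows that the read-out can respond strongly to a change on the amine-bearing chain, which the earlier step, a number 8.6 percentage points lower from compound 1 to compound 2 (within the scatter), did not show. The entering group has 7 heavy atoms, all carbon, with one six-membered non-aromatic ring, and no measurement shown explains why adding it is followed by such a large step.

The compounds shown leave open whether the ring of cyclohexylmethyl is needed on this carbon, or whether a plain butyl chain, a benzyl group or a cyclohexylmethyl group carrying an amine would give a similar number. They also leave open how compound 4 would compare over a range of concentrations, as the read-out here is the size of the inhibition at one concentration and not a potency.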